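Swapping the Sulfur-Bearing Tail for a Cyano Tail

The source may report more compounds than this note shows. Statements on the series, on what has been measured and on what is new or still open speak of the compounds shown alone.

Three compounds share one core and differ only in the chain and group hanging from its aromatic nitrogen. Compound 1 `C/N=C(/NC#N)NCCCn1nc(-c2ccccc2)ccc1=O` gives 40.5% in a functional assay on the whole organism with Rattus norvegicus as the target, at a dose of 100 mg/kg (on this read-out higher numbers stand for more inhibition at the one dose given (going by the name of the read-out) and lower numbers for less inhibition), compound 2 `C/N=C(\S)NCCCCCn1nc(-c2ccccc2)ccc1=O` gives 68.9%, and compound 3 `O=c1ccc(-c2ccccc2)nn1CCCCNC(=S)NC1CCCCC1` gives 18.1%. Compound 2 thus has the highest number of the three, and its lead over the others is beyond the scatter of the measurement.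

The next compound, compound 4 `C/N=C(/NC#N)NCCCCCn1nc(-c2ccccc2)ccc1=O`, keeps the five-carbon chain of compound 2 and changes only the group at its end: a group of 6 heavy atoms (3 carbon, 3 nitrogen; no ring) in place of a group of 4 heavy atoms (2 carbon, 1 nitrogen, 1 sulfur; no ring), on an amine nitrogen.

For the measured compounds named here, only one measured step speaks to this: a number 28.4 percentage points higher from compound 1 to compound 2 (beyond the scatter), where the sulfur-bearing tail on a longer chain replaced the cyano-bearing tail on a shorter chain. Compound 4 undoes the group part of that step but keeps the longer chain, so a drop is expected, smaller than the earlier rise. The expected step is a number 18.9 percentage points lower from compound 2 to compound 4 (beyond the scatter). For compound 4 the estimate in this assay is 50%, ranging from 30% to 70%.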

Compound 4, a percentage reported as inhibition, in the whole organism at one dose (the size of the read-out at that dose, not a potency): 47.6%
Compound 4: middle estimate off by 2.4 percentage points, on the high side; the measured number falls inside the stated range.
By their numbers in this assay, from the lowest: compound 3; then compounds 1 and 4 (each within the scatter of the next); then compound 2.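

With the chain held the same and only the end group on the amine nitrogen changed, this assay shows a number 21.3 percentage points lower from compound 2 to compound 4 (beyond the scatter), so this step isolates the end group, which the earlier step could not do because chain and group changed together. With the nitrile-bearing group in place, compound 1 gives 40.5% and compound 4 gives 47.6%, values within the scatter of each other, so the chain difference between these two compounds shows no clear effect on the number at this dose. No measurement here accounts for the difference between the two end groups.

From the compounds shown here alone, how the sulfur-bearing group would read on the chain of compound 1 remains open. So does the outcome of putting a simple amine or a carboxylic acid at this end, or of a longer chain.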